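Trifluoromethoxy for fluoro on the benzylamino group

The compounds below may be only part of what the source reports. "The series", "measured", "known", "first", "only" and "open" are said of these compounds alone.

The series rests on a shared nucleoside core carrying a benzylamino group. Compound 1 `OC[C@H]1O[C@@H](n2cnc3c(NCc4ccccc4F)ncnc32)[C@H](O)[C@@H]1O` bears a fluoro group on that aromatic ring. Compound 2 `OC[C@H]1O[C@@H](n2cnc3c(NCc4ccc(C(F)(F)F)cc4)ncnc32)[C@H](O)[C@@H]1O` carries a trifluoromethyl group instead. In a functional assay on G-361 cells (Homo sapiens) for antiproliferative activity, with a stated time of 72 h (on this read-out higher numbers stand for weaker inhibition and lower numbers for stronger inhibition), compound 1 is recorded as "not determined" (no result reported), so no number places it on the scale. In this assay compound 2 reaches only a limit, > 166000 nM, and not a measured number; the same holds where (the limit of > 166000 nM in this assay, at which 1 of the 2 values shown sits). Compound 3 `OC[C@H]1O[C@@H](n2cnc3c(NCc4ccccc4OC(F)(F)F)ncnc32)[C@H](O)[C@@H]1O` is the next member, related to compound 1 by trifluoromethoxy in place of fluoro on an aromatic carbon. Within the data shown here, with no measured step between compound 1 and compound 2, no size is given for this change; the expectation is a step of no more than the scatter, in no settled direction. For compound 3 the expected result in this assay is 100000 nM, with a range from 20000 nM to 300000 nM.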

Compound 3, half-maximal inhibitory concentration: > 166000 nM
Compound 3 was reported as a limit; the forecaster's own chance of this, stated with the estimate: 60%; at least 1.6-fold (0.22 log units) between middle value and limit.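

Compound 3 gives > 166000 nM in this assay as a limit and not a number. Compound 1 has no number there, so no step can be read between compound 1 and compound 3. From the compounds shown here alone, whether trifluoromethoxy in place of fluoro changes antiproliferative activity at all stays open.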